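A Piperazine Amide Gains a Trifluoromethylbenzyl Arm

The source may hold more compounds than are shown below. What is called first, only, known or untested is meant among the compounds shown, and "the series" means these compounds.

Compound 1 `COC(=O)c1ccc(O)c(NC(=O)C(C)(C)Oc2ccc(C(C)(C)CC(C)(C)C)cc2)c1` and compound 2 `COC(=O)c1cccc(NC(=O)COc2ccc(C(C)(C)CC(C)(C)C)cc2)c1` both carry an anilide on the shared aryloxyacetamide core. In an assay on isolated protein for inhibition of malate dehydrogenase, mitochondrial (Homo sapiens), with a stated time of 30 min (on this read-out lower numbers stand for stronger inhibition and higher numbers for weaker inhibition), compound 1 gives 11000 nM and compound 2 gives 8920 nM. Compound 3 `C#CCN1CCN(C(=O)COc2ccc(C(C)(C)CC(C)(C)C)cc2)CC1` carries a piperazine amide instead of the anilide. In this assay compound 3 reaches only a limit, > 40000 nM, and so stands at the limit of > 40000 nM in this assay, at which 1 of the 3 values shown sits. Compound 4 `CC(C)(C)CC(C)(C)c1ccc(OCC(=O)N2CCN(Cc3ccc(C(F)(F)F)cc3)CC2)cc1` differs from compound 3 by 4-(trifluoromethyl)phenyl in place of ethynyl on a saturated chain carbon bound to an amine nitrogen in a ring. Among the compounds with values here, no measured pair shows this change, so its size is unknown. The step of an at least 1.6-fold lower number from compound 3 to compound 4 (0.20 log units; that floor lies within the scatter) is expected to be toward stronger inhibition, but only modestly, given that compound 3 sits at the limit of > 40000 nM in this assay, at which 1 of the 3 values shown sits. Compound 4 is therefore estimated at about 25000 nM, between 8000 nM and 80000 nM.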

Compound 4, half-maximal inhibitory concentration: 5400 nM
Compound 4: middle estimate off by 4.6-fold (0.67 log units), on the high side, outside the stated range (below it).
By their numbers in this assay, from the lowest: compounds 4, 2 and 1 (each within the scatter of the next, the first and the last beyond it). At a limit, above all of these: compound 3.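

Within the data shown here, on the saturated chain carbon bound to an amine nitrogen in a ring, the change from propargyl to 4-(trifluoromethyl)benzyl gives the first measured number for a piperazine amide: in this assay it brings an at least 7.4-fold lower number from compound 3 to compound 4 (0.86 log units; beyond the scatter). This position therefore accepts the much larger aromatic arm, with a gain beyond the scatter. The true size of that gain stays open, since compound 3 stands only at a limit: the limit of > 40000 nM in this assay, at which 1 of the 4 values shown sits.

The compounds shown also leave open whether the phenyl ring or the trifluoromethyl group carries the step; an unsubstituted benzyl on that nitrogen would separate the two.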